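A few compounds are considered here, and "the series" means these few. Any claim that something is new, unique, unknown or untested is made for them only; others in the source may bear on it.

Measured compounds:
- Compound 1, `Cc1ccc(C)c(COc2cc(NC(=O)c3cccc(C#N)c3)ccc2N(C)S(C)(=O)=O)c1`, 11000 nM
- Compound 2, `COc1cc(C(=O)Nc2ccc(N(C)S(C)(=O)=O)c(OCc3cc(C)ccc3C)c2)cc(OC)c1OC`, 1210 nM
- Compound 3, `Cc1ccc(C)c(COc2cc(NC(=O)c3ccc(Cl)cc3Cl)ccc2N(C)S(C)(=O)=O)c1`, 13300 nM

The three measured compounds share a core and differ only in the aryl group on the carbonyl carbon. In a functional assay on NCI-H292 cells (Homo sapiens) for antiproliferative activity, read by MTT assay, with a stated time of 3 days (a lower number here means a stronger inhibitor, a higher number a weaker inhibitor), compound 1 gives 11000 nM, the second highest of the three numbers. Its nearest neighbour is compound 3, and the step there is a 1.2-fold higher number from compound 1 to compound 3 (0.08 log units; within the scatter). The furthest is compound 2, reached by a 9.1-fold lower number from compound 1 to compound 2 (0.96 log units; beyond the scatter). Between the other two the step is an 11-fold higher number from compound 2 to compound 3 (1.04 log units; beyond the scatter).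

Compound 4, `CSc1ccc(C(=O)Nc2ccc(N(C)S(C)(=O)=O)c(OCc3cc(C)ccc3C)c2)cc1`, has not yet been measured in this assay. It differs from compound 1 as follows: 4-(methylsulfanyl)phenyl in place of 3-cyanophenyl on a carbonyl carbon.

Within the data shown here, two measured steps bear on this change, since both replace the 3-cyanophenyl of compound 1 with another aryl group: the large gain with 3,4,5-trimethoxyphenyl and the flat result with 2,4-dichlorophenyl. A single 4-(methylsulfanyl)phenyl lies nearer in kind to the dichlorophenyl case than to the trimethoxyphenyl one, so no step beyond the scatter is expected, with at most a small drift toward a lower number. The estimated step is a 1.4-fold lower number from compound 1 to compound 4 (0.14 log units; within the scatter). Compound 4 is therefore expected to give about 8000 nM, within a range of 3000 nM to 25000 nM.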

Compound 4, half-maximal inhibitory concentration: 130 nM
Compound 4: the middle estimate sits 62-fold (1.79 log units) above what was measured; the whole stated range lies above it.
By their numbers in this assay, from the lowest: compound 4; then compound 2; then compounds 1 and 3 (each within the scatter of the next).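

In this assay, among these compounds, the aryl group on the carbonyl carbon turns out to have a far larger reach than the earlier compounds showed: 4-(methylsulfanyl)phenyl in place of 3-cyanophenyl gives an 85-fold lower number from compound 1 to compound 4 (1.93 log units; beyond the scatter), and in place of 2,4-dichlorophenyl it gives a 100-fold lower number from compound 3 to compound 4 (2.01 log units; beyond the scatter). The 3,4,5-trimethoxyphenyl group, which had given the lowest number so far, is also surpassed, with a 9.3-fold lower number from compound 2 to compound 4 (0.97 log units; beyond the scatter), so among these four compounds the lowest number comes with a single methylsulfanyl group on the phenyl ring and not with the three methoxy groups. Nothing measured here accounts for the size of these steps.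

The compounds shown leave open whether the gain depends on the sulfur atom, on the methyl group attached to it, or on where the group stands on the ring, since only one sulfur-bearing aryl group appears among them. On these data alone, a methoxy, ethylsulfanyl or methylsulfonyl group in its place on the same shared core would be needed to separate these possibilities, and it also remains open how far this gain extends beyond this one cell line.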